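Removing the hydroxy group from compound 3

This account rests on a few compounds, and the source may have more. Where it says the series, first, only, none or still open, it means among the compounds named here.

Three analogues sharing one core have been measured in a functional assay on MCF7 cells (Homo sapiens) for antiproliferative activity, read by MTT assay, with a stated time of 72 h; on this read-out higher numbers stand for weaker inhibition and lower numbers for stronger inhibition. Compound 1 `CCCSc1nc(N/N=C/c2ccccc2F)c2nnn(Cc3ccccc3)c2n1` returns only a limit of the assay, > 64000 nM, and not a number. Compound 2 `CCCSc1nc(N/N=C/c2cccnc2)c2nnn(Cc3ccccc3)c2n1` gives 58700 nM in this assay, and compound 3 `CCCSc1nc(N/N=C(\C)c2ccc(O)cc2)c2nnn(Cc3ccccc3)c2n1` gives 21600 nM. Compound 3 therefore holds the lowest of the two numbers shown; the nearest is compound 2, as the step of a 2.7-fold lower number from compound 2 to compound 3 (0.43 log units; beyond the scatter) shows, and the step of an at least 2.9-fold lower number from compound 1 to compound 3 (0.47 log units; beyond the scatter) points the same way, while an at least 1.0-fold lower number from compound 1 to compound 2 (0.03 log units; that floor lies within the scatter) stays within the scatter.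

Compound 4 `CCCSc1nc(N/N=C(\C)c2ccccc2)c2nnn(Cc3ccccc3)c2n1` differs from compound 3 in one place: hydrogen in place of hydroxy on an aromatic carbon. Among the measured compounds shown here, no measured step isolates this change; the two steps that reach compound 3 exchange the whole aryl group and, from compound 1, also the carbon bearing the double bond to nitrogen, so they show only that the hydroxy-bearing analogue gave the lowest number. On that indirect basis a small rise in number is expected for compound 4, of the size a 1.6-fold higher number from compound 3 to compound 4 (0.21 log units; within the scatter), though a result within the scatter of compound 3 would not surprise. Compound 4 is estimated at 35000 nM, with a range from 12000 nM to 90000 nM.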

Compound 4, half-maximal inhibitory concentration: 32100 nM
Beside the measured number, compound 4's estimate is 1.1-fold (0.04 log units) above it; the measured number falls inside the stated range.
By their numbers in this assay, from the lowest: compounds 3, 4 and 2 (each within the scatter of the next, the first and the last beyond it). At a limit, above all of these: compound 1.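

Among the compounds shown here, the step (a 1.5-fold higher number from compound 3 to compound 4 (0.17 log units; within the scatter)) is the first direct reading of this change in this assay, and it shows that going from 4-hydroxyphenyl to phenyl, on an aromatic carbon para to a large group, does not move the number beyond the scatter. For the compounds shown here, the hydroxy group is therefore not needed for the number that compound 3 gave, although the earlier steps had left open whether it mattered. Without that group the gap to the pyridin-3-yl analogue also closes, since the step (a 1.8-fold lower number from compound 2 to compound 4 (0.26 log units; within the scatter)) lies within the scatter, and the remaining step (an at least 1.9-fold lower number from compound 1 to compound 4 (0.29 log units; that floor lies within the scatter)) starts from a limit and not a number, so it separates nothing: (the limit of > 64000 nM in this assay, at which 1 of the 4 values shown sits).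

The compounds shown leave open whether another group on the same aromatic carbon, such as a methoxy group, an amine or a carboxylic acid, would shift the number beyond the scatter in this assay. They also leave open what a longer chain on the sulfur or a different group on the ring nitrogen in place of benzyl would do, since all four compounds carry the same pair.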